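Cyclopropyl for neopentyl on the amine of compound 3

The source may report more compounds than this note shows. Statements on the series, on what has been measured and on what is new or still open speak of the compounds shown alone.

In a functional assay for inhibition of B1 bradykinin receptor (Homo sapiens), read by calcium flux (on this read-out lower numbers stand for stronger inhibition and higher numbers for weaker inhibition), compound 1 `CC(C)(C)NCc1ccc2c(c1)CCC[C@H]2NC(=O)C[C@@H]1CCCCN1S(=O)(=O)c1cccc(Cl)c1` gives 73 nM. Its isoquinolinyl analogue, compound 2 `CC(C)(C)NCc1ccc2c(c1)CCC[C@H]2NC(=O)C[C@@H]1CCCCN1S(=O)(=O)c1cccc2cnccc12`, gives 4300 nM in this assay, and that step is a 59-fold higher number from compound 1 to compound 2 (1.77 log units; beyond the scatter). Compound 3 `CC(C)(C)CNCc1ccc2c(c1)CCC[C@H]2NC(=O)C[C@@H]1CCCCN1S(=O)(=O)c1cccc(C(F)(F)F)c1` gives 230 nM in this assay, which places it second highest of the three numbers: it stands nearer to compound 1 and furthest from compound 2. Among the compounds with values here, compound 3 differs from compound 1 in two places at once, so their two values show only that the pair lies apart. The step to compound 4 `O=C(C[C@@H]1CCCCN1S(=O)(=O)c1cccc(C(F)(F)F)c1)N[C@@H]1CCCc2cc(CNC3CC3)ccc21` is cyclopropyl in place of neopentyl on an amine nitrogen. Within the data shown here, no measured step touches the substituent on that amine nitrogen; the single step recorded, the one from compound 1 to compound 2, changes the aryl on the sulfonyl sulfur and says nothing about the amine. Compound 4 is therefore expected to stay close to compound 3, with a step of a 1.1-fold higher number from compound 3 to compound 4 (0.04 log units; within the scatter) in this assay that need not exceed the scatter. The estimate for compound 4 in this assay is 250 nM, ranging from 70 nM to 900 nM.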

Compound 4, half-maximal inhibitory concentration: 47 nM
Compound 4: the middle estimate sits 5.3-fold (0.73 log units) above what was measured; the measured number lies below the stated range.
By their numbers in this assay, from the lowest: compounds 4 and 1 (each within the scatter of the next); then compound 3; then compound 2.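

The substituent on the amine nitrogen matters in this assay: with the rest of the molecule unchanged, the step is a 4.9-fold lower number from compound 3 to compound 4 (0.69 log units; beyond the scatter), which lies beyond the scatter. Within the data shown here, the earlier step changed only the aryl on the sulfonyl sulfur, so this is the first measured sign that the group on the amine moves the number, and here cyclopropyl, with 3 heavy atoms against the 5 of neopentyl, goes with the lower number. No measurement at hand accounts for this change, which therefore stands as an observation only.

This single pair cannot separate the presence of the ring from the smaller group, and isopropyl or cyclobutyl on the same nitrogen would bear on that. From the compounds shown here alone, it also remains open whether the same change holds with the 3-chlorophenyl of compound 1 on the sulfonyl sulfur.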